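Swapping Trifluoromethyl for Chloro in Compound 1

The source may hold more compounds than are shown below. What is called first, only, known or untested is meant among the compounds shown, and "the series" means these compounds.

Three compounds were measured in an assay for inhibition of MAP kinase-interacting serine/threonine-protein kinase 2 (Homo sapiens), read by luminescence and ADP-Glo, with a stated time of 2 h; on this read-out lower numbers stand for stronger inhibition and higher numbers for weaker inhibition. Compound 1 `O=c1ccc(-c2ccc3cn[nH]c3c2)cn1Cc1ccccc1C(F)(F)F` gives 100 nM, the highest number of the three. Compound 3 `O=c1ccc(-c2n[nH]c3ncc(Br)cc23)cn1Cc1ccccc1` gives 12 nM, and compound 2 `Nc1n[nH]c2cc(-c3ccc(=O)n(Cc4ccccc4F)c3)ccc12` gives 4 nM; both of their gaps to compound 1 lie beyond the scatter. Compound 4 `O=c1ccc(-c2ccc3cn[nH]c3c2)cn1Cc1ccccc1Cl` has not yet been measured. It differs from compound 1 by a single change: chloro in place of trifluoromethyl on an aromatic carbon. Going by the values given here, no measured pair shows this exchange, so the numbers give nothing to set its size; the step is expected to be small, within the scatter, in either direction. On that basis compound 4 is estimated to give 80 nM in this assay, with a range from 30 nM to 250 nM. That amounts to an expected step of a 1.3-fold lower number from compound 1 to compound 4 (0.10 log units; within the scatter).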

Compound 4, half-maximal inhibitory concentration: 78 nM
Compound 4: middle estimate off by 1.0-fold (0.01 log units), on the high side; low and high end bracket the measured number.
By their numbers in this assay, from the lowest: compound 2; then compound 3; then compounds 4 and 1 (each within the scatter of the next).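

In this assay, chloro in place of trifluoromethyl on this aromatic carbon, ortho to a large group, gives a 1.3-fold lower number from compound 1 to compound 4 (0.11 log units; within the scatter). At this position, on the core of compound 1, a group of 1 heavy atom and one of 4 heavy atoms therefore cannot be told apart. No available evidence bears on why the two groups read alike. As far as these compounds go, it remains open whether a methoxy group, an amine or a carboxylic acid on this carbon would shift the number beyond the scatter. From the compounds shown here alone, whether the same exchange reads alike on another core also remains open.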